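Lengthening the Amide Chain on a Methoxy Aminophenyl Pyrazoline

This account rests on a few compounds, and the source may have more. Where it says the series, first, only, none or still open, it means among the compounds named here.

Of the compounds shown here, two have been measured in an assay on isolated protein for inhibition of Nitric oxide synthase, inducible (Homo sapiens), with a stated time of 30 min, tested at 1 mM (on this read-out higher numbers stand for more inhibition at the one concentration tested (going by the name of the read-out) and lower numbers for less inhibition), so far. Compound 1, `CCCC(=O)N1CCC(c2cc(Cl)ccc2N)=N1`, gives 0.29% in this assay. Compound 2, `COc1ccc(N)c(C2=NN(C(C)=O)CC2)c1`, gives 20.4% in this assay, and so stands higher of the two numbers, the gap to compound 1 being beyond the scatter. Compound 1 and compound 2 differ from each other in more than one place, so what drives that gap cannot be told from these two alone.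

Compound 3, `CCCCC(=O)N1CCC(c2cc(OC)ccc2N)=N1`, has not yet been measured in this assay. It differs from compound 2 in a single place: propyl in place of hydrogen on a saturated chain carbon bound to a carbonyl carbon. Compound 1 also carries a longer chain on its carbonyl than compound 2 and gives the low number, yet its other difference from compound 2 leaves this open. A step downward of moderate size, a number 10.4 percentage points lower from compound 2 to compound 3 (beyond the scatter), is expected, though a change no larger than the scatter would not be surprising. Compound 3 is estimated to give 10% in this assay, within a range from 0% to 30%.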

Compound 3, a percentage reported as inhibition, at one concentration (the size of the read-out at that concentration, not a potency): 0.18%
Beside the measured number, compound 3's estimate is 9.8 percentage points above it; measured number inside the range.
By their numbers in this assay, from the lowest: compounds 3 and 1 (each within the scatter of the next); then compound 2.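

In this assay, the amide chain now has a comparison that changes in one place only: a number 20.2 percentage points lower from compound 2 to compound 3 (beyond the scatter), with propyl in place of hydrogen on a saturated chain carbon bound to a carbonyl carbon. Within the data shown here, the earlier pair differed in more than one place, so this is the first result that ties a change in the number to this position alone; on this core, going from acetyl to butylcarbonyl removes nearly all of the inhibition seen at the one concentration tested, leaving compound 3 at 0.18%. Nothing available explains why the longer chain gives the lower number.

From the compounds shown here alone, with only hydrogen and propyl compared at this place, it remains open how the number changes along the chain: a methyl or ethyl group in place of that hydrogen would show whether the loss builds gradually or appears all at once, and a chain ending in an amine or a carboxylic acid would show whether a group other than plain carbon can restore inhibition. Going by these compounds, it also remains open whether the same step would appear with a chlorine or another group in place of the methoxy on the core.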